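The source may report more compounds than this note shows. Statements on the series, on what has been measured and on what is new or still open speak of the compounds shown alone.

Measured compounds in an in vitro assay on BHK cells for displacement of a labelled ligand from Glucagon receptor (Homo sapiens), read by scintillation proximity assay; a lower number here means a stronger inhibitor, a higher number a weaker inhibitor:
- compound 1 `O=C(O)CCNC(=O)c1ccc(CC(c2ccc(Cl)cc2)c2nc(-c3ccc(C(F)(F)F)cc3)cs2)cc1` gives 96 nM
- compound 2 `O=C(O)CCNC(=O)c1ccc(CN(c2ccc(Cl)cc2)c2nc(-c3ccc(C(F)(F)F)cc3)cs2)cc1` gives 76 nM
- compound 3 `Cc1cc(N(Cc2ccc(C(=O)NCCC(=O)O)cc2)c2nc(-c3ccc(C(F)(F)F)cc3)cs2)ccc1C(C)C` gives 119 nM

Compound 3 carries the highest of the three numbers in this assay, but its gaps to compound 1 and to compound 2 both lie within the scatter, so no order among the three can be read from these values.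

Compound 4 `O=C(O)CCNC(=O)c1ccc(CN(c2ccc3c(c2)CCC3)c2nc(-c3ccc(C(F)(F)F)cc3)cs2)cc1` is the next member. Its change from compound 3 is 2,3-dihydro-1H-inden-5-yl in place of 4-isopropyl-3-methylphenyl on a nitrogen on an aromatic ring.

Within the data shown here, the one measured step that bears on this position is a 1.6-fold higher number from compound 2 to compound 3 (0.19 log units; within the scatter), a swap of the aryl group on the same nitrogen that stayed within the scatter. Among the measured compounds shown here, no measured step covers the dihydroindenyl group itself. For the measured compounds named here, with only one precedent, and that one flat, no movement beyond the scatter is expected for the new aryl group on the nitrogen.

Compound 4 is therefore estimated at 100 nM, with a range of 40 nM to 250 nM; the expected step is a 1.2-fold lower number from compound 3 to compound 4 (0.08 log units; within the scatter), held close to flat because a 1.6-fold higher number from compound 2 to compound 3 (0.19 log units; within the scatter) was flat.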

Compound 4, half-maximal inhibitory concentration: 86 nM
Estimate against measurement, compound 4: 1.2-fold (0.07 log units) above; measured number inside the range.
By their numbers in this assay, from the lowest: compounds 2, 4, 1 and 3 (each within the scatter of the next).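

In this assay, the 2,3-dihydro-1H-inden-5-yl group on this nitrogen gives a 1.4-fold lower number from compound 3 to compound 4 (0.14 log units; within the scatter) and, against 4-chlorophenyl, a 1.1-fold higher number from compound 2 to compound 4 (0.05 log units; within the scatter). The position now carries three different aryl groups whose numbers all lie within the scatter of one another, and closing the five-membered non-aromatic ring of carbon produces no readable change from the open 4-isopropyl-3-methylphenyl group. No available data bear on the reason for this flat reading.

The compounds shown leave open whether an amine or a carboxylic acid on this aryl group would move the number beyond the scatter. Also open, on these data alone, is how the 2,3-dihydro-1H-inden-5-yl group reads on the carbon that stands in place of this nitrogen in compound 1.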